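The compounds below may be only part of what the source reports. "The series", "measured", "known", "first", "only" and "open" are said of these compounds alone.

Compound 1 `COc1cc(OC)cc(-n2c(-c3ccccc3)nc(C)c2C)c1` was examined in a functional assay, read by spectrophotometry, with a stated time of 60 min, tested at 40 uM (a higher number here means a stronger effect of the compound at the concentration tested, a lower number a weaker effect), where compound 1 gives 47.1%. A second compound, compound 2 `COc1ccc(-n2c(-c3ccccc3)nc(C)c2C)cc1`, was measured in this assay as well, and compound 2 gives 43.7%. Compound 1 holds the higher of the two numbers, but the gap between compound 1 and compound 2 lies within the usual scatter of such measurements, so the two results cannot be told apart. Compound 3 `COc1cc(OC)cc(-n2c(-c3ccc(F)cc3)nc(C)c2C)c1` differs from compound 1 in a single place: fluoro in place of hydrogen on an aromatic carbon. Going by the values given here, no measured pair in this set shows what such a change does in this assay, so there is no step to lean on. With only the two results of compound 1 and compound 2 as a guide, compound 3 is expected to give a number close to that of compound 1, and the step of a number 0.1 percentage points lower from compound 1 to compound 3 (within the scatter) is estimated to stay within the scatter, in no clear direction. Compound 3 is therefore expected to give about 47% in this assay, with a range from 32% to 62%.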

Compound 3, a percentage reported as activity, at one concentration (the size of the read-out at that concentration, not a potency): 47.1%
The estimate for compound 3 lay 0.1 percentage points below the measured number, and the stated range covers the measured number.
By their numbers in this assay, from the lowest: compounds 2, 1 and 3 (each within the scatter of the next).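

Fluoro in place of hydrogen on an aromatic carbon, para to a large group, gives the first measured step at this position in this assay (no change at the digits printed from compound 1 to compound 3 (within the scatter)). The earlier compounds shown here carried no fluoro and could not show this; the phenyl to 4-fluorophenyl change leaves the read-out of compound 3 level with that of compound 1 at the single concentration tested. Nothing available here bears on why the read-out holds at this position.

From the compounds shown here alone, what stays open is whether another group at this same place, such as an amine, a carboxylic acid or a longer chain, would move the read-out beyond the scatter. Going by these compounds, it also remains open whether fluoro would behave the same way on a different aromatic carbon of the compound.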